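This account rests on a few compounds, and the source may have more. Where it says the series, first, only, none or still open, it means among the compounds named here.

Compound 1, `CCOC(=O)[C@]12C[C@@H]1[C@@H](n1ccc3c(NCCCc4ccc(OC)c(O)c4)nc(C#Cc4ccccc4)nc31)[C@H](O)[C@@H]2O`: in an assay on isolated protein for binding affinity to adenosine receptor A3 (Homo sapiens) (a higher number here means a weaker inhibitor, a lower number a stronger inhibitor), compound 1 gives >= 99 nM, a limit of the assay rather than a number.
Compound 2, `Fc1ccc(C#CC2=NC3=NC=NC3C(NCc3cccc(Cl)c3)=N2)cc1F`: in this assay compound 2 gives >= 99 nM, again a limit.
Compound 3, `CNC(=O)[C@]12C[C@@H]1[C@@H](n1cnc3c(NCc4cccc(Cl)c4)nc(C#Cc4ccccc4)nc31)[C@H](O)[C@@H]2O`: in this assay compound 3 gives >= 99 nM, also a limit.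

Compound 3 therefore stands at the same limit as every other measured compound here (the limit of >= 99 nM in this assay, at which 3 of the 3 values shown sit), so nothing separates it from compound 1 or compound 2. Compound 4, `CNC(=O)[C@]12C[C@@H]1[C@@H](n1cnc3c(NCc4cccc(Cl)c4)nc(C#Cc4ccc(Cl)s4)nc31)[C@H](O)[C@@H]2O`, differs from compound 3 by 5-chlorothiophen-2-yl in place of phenyl on a triple-bonded carbon. Within the data shown here, no measured pair covers this change, so there is no direct guide to its size. Since every measured value is only a limit, the step from compound 3 to compound 4 is expected to be a step that the limit leaves unreadable from compound 3 to compound 4, with no shift beyond the scatter claimed. In this assay compound 4 is estimated at 200 nM, within a range from 60 nM to 2000 nM.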

Compound 4, inhibition constant: >= 99 nM
Compound 4 gave a limit, no number (the forecaster's own chance of this, stated with the estimate: 70%); the middle value is on the limit's open side.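

Compound 3 and compound 4 both sit at a limit of the assay rather than at a number, so no step can be read between them: the limit of >= 99 nM in this assay, at which 4 of the 4 values shown sit.

The compounds shown leave open how strongly any of them binds in this assay, and whether 5-chlorothiophen-2-yl in place of phenyl changes that at all.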